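Dopamine transporter inhibition: removing the hydroxy group from compound 2

The source may hold more compounds than are shown below. What is called first, only, known or untested is meant among the compounds shown, and "the series" means these compounds.

Measured compounds:
compound 1, `O=c1[nH]nc(C[S+]([O-])C(c2ccccc2)c2ccccc2)s1`, 38100 nM
compound 2, `Cc1cc(O)nc(C[S+]([O-])C(c2ccccc2)c2ccccc2)n1`, 109000 nM
compound 3, `[O-][S+](Cc1csc(Br)c1)C(c1ccccc1)c1ccccc1`, 16600 nM

All three compounds share a core and differ only in the aromatic ring attached on a saturated chain carbon bound to a sulfur. In an assay on HEK293 cells for inhibition of sodium-dependent dopamine transporter (Homo sapiens), read by scintillation counting, with stated times of 5 min and 1 min (a lower number here means a stronger inhibitor, a higher number a weaker inhibitor), compound 2 stands highest of the three numbers; its nearest neighbour is compound 1, with a 2.9-fold higher number from compound 1 to compound 2 (0.46 log units; beyond the scatter), and the furthest is compound 3, with a 6.6-fold lower number from compound 2 to compound 3 (0.82 log units; beyond the scatter). Compound 1 and compound 3 are separated by a 2.3-fold lower number from compound 1 to compound 3 (0.36 log units; beyond the scatter).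

The unmeasured compound 4, `Cc1cnc(C[S+]([O-])C(c2ccccc2)c2ccccc2)nc1`, is reached from compound 2 by 5-methylpyrimidin-2-yl in place of 4-hydroxy-6-methylpyrimidin-2-yl on a saturated chain carbon bound to a sulfur. Going by the values given here, no measured pair changes the ring in just this way, so the bearing steps are indirect. The two steps leaving the core of compound 2, to compound 1 and to compound 3, both lower the number, one modestly and one more so, so the ring bearing the hydroxy group is associated with the weakest inhibition seen here. Among the compounds with values here, on that basis a modest fall is expected for compound 4, as a step of a 2.4-fold lower number from compound 2 to compound 4 (0.38 log units; beyond the scatter), though the range is wide because none of the measured steps isolates this change. Compound 4 is estimated at 45000 nM, between 15000 nM and 135000 nM.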

Compound 4, half-maximal inhibitory concentration: 156000 nM
Beside the measured number, compound 4's estimate is 3.5-fold (0.54 log units) below it; the measured number lies above the stated range.
By their numbers in this assay, from the lowest: compound 3; then compound 1; then compounds 2 and 4 (each within the scatter of the next).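

In this assay, the step to 5-methylpyrimidin-2-yl from 4-hydroxy-6-methylpyrimidin-2-yl on a saturated chain carbon bound to a sulfur gives a 1.4-fold higher number from compound 2 to compound 4 (0.16 log units; within the scatter), so the hydroxy group, lost here together with a shift in where the methyl group stands, does not separate these two compounds in this assay. Going by these compounds alone, the separation now follows the ring type across all four compounds, with no compound going against it: both compounds with a six-membered aromatic ring stand apart from the two with a five-membered one, as in a 9.4-fold higher number from compound 3 to compound 4 (0.97 log units; beyond the scatter) and in a 4.1-fold higher number from compound 1 to compound 4 (0.61 log units; beyond the scatter). No supporting information is available that would explain these results.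

Since this single step alters the hydroxy group and the methyl group together, the compounds shown leave open what each does alone, and whether an amine in place of the hydroxy group would also leave the number within the scatter of compound 2. They also leave open how much of the lower number of compound 3 goes with its bromine, which an unsubstituted thiophen-3-yl group would address.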